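This account rests on a few compounds, and the source may have more. Where it says the series, first, only, none or still open, it means among the compounds named here.

In a functional assay on A549 cells (Homo sapiens) for antiproliferative activity, read by MTT assay (a lower number here means a stronger inhibitor, a higher number a weaker inhibitor), compound 1 `COc1cc2c(Oc3ccc(NC(=O)Nc4ccccc4F)cc3)ccnc2cc1OCCCCCCC(=O)NO` gives 870 nM, compound 2 `COc1cc2c(Oc3ccc(NC(=O)Nc4ccc(C)cc4C)cc3)ccnc2cc1OCCCCCCC(=O)NO` gives 5490 nM and compound 3 `COc1cc2c(Oc3ccc(NC(=O)NC4CCCCC4)cc3)ccnc2cc1OCCCCCCC(=O)NO` gives 850 nM. All three share one core and vary only in the group on an amide-type nitrogen. Compound 3 stands level with compound 1, the swap between them being a 1.0-fold lower number from compound 1 to compound 3 (0.01 log units; within the scatter). Compound 2 lies apart from both, with a 6.3-fold higher number from compound 1 to compound 2 (0.80 log units; beyond the scatter) and a 6.5-fold lower number from compound 2 to compound 3 (0.81 log units; beyond the scatter).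

Compound 4 `COc1cc2c(Oc3ccc(NC(=O)NNC(=O)c4ccccc4)cc3)ccnc2cc1OCCCCCCC(=O)NO` changes that same place, with benzamido in place of cyclohexyl on an amide-type nitrogen. Within the data shown here, none of the measured compounds carries benzamido, so the three steps show only how far a swap here has moved the number. One swap, a 1.0-fold lower number from compound 1 to compound 3 (0.01 log units; within the scatter), moved it by nothing beyond the scatter, while the swap to compound 2, a 6.3-fold higher number from compound 1 to compound 2 (0.80 log units; beyond the scatter), was modest. Compound 1 and compound 3 sit together at the low end of the three numbers, so a modest step in this assay towards a higher number seems the likelier outcome, though the data cannot exclude no change. The expected step is a 2.4-fold higher number from compound 3 to compound 4 (0.37 log units; beyond the scatter). For compound 4 the estimated value is 2000 nM, with an expected range of 600 nM to 6500 nM.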

Compound 4, half-maximal inhibitory concentration: 2820 nM
Estimate against measurement, compound 4: 1.4-fold (0.15 log units) below; the range from low to high includes it.
By their numbers in this assay, from the lowest: compounds 3 and 1 (each within the scatter of the next); then compounds 4 and 2 (each within the scatter of the next).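

In this assay, benzamido, which carries a hydrogen-bond donor and a hydrogen-bond acceptor where cyclohexyl carries neither, gives a 3.3-fold higher number from compound 3 to compound 4 (0.52 log units; beyond the scatter) and, against the 2-fluorophenyl group, a 3.2-fold higher number from compound 1 to compound 4 (0.51 log units; beyond the scatter), so this change takes the compound out of the low pair formed by compound 1 and compound 3. With a 1.9-fold lower number from compound 2 to compound 4 (0.29 log units; within the scatter), compound 4 stands level with compound 2, so the four compounds fall into two levels, and the presence of an aromatic ring on this side of the nitrogen does not sort them: compound 1 carries such a ring and stays with cyclohexyl-bearing compound 3, while compound 2 and compound 4 carry such rings at the higher level. The study as shown offers no evidence that explains why these groups fall at these two levels.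

The compounds shown leave open where a plain phenyl or an acetamido group on this nitrogen would fall, which would help separate the contribution of the benzene ring from that of the added carbonyl and nitrogen. They also leave open whether benzamido would give the same step on a core with a shorter or longer chain ending in the hydroxamic acid.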